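The compounds below may be only part of what the source reports. "The series", "measured", "known", "first", "only" and "open" are said of these compounds alone.

Of the compounds shown here, three built on one shared core have been tested in a functional assay on HepG2 cells (Homo sapiens) for antiproliferative activity, read by MTT assay, with a stated time of 72 h; on this read-out lower numbers stand for stronger inhibition and higher numbers for weaker inhibition. Compound 1 `C=C(Cl)C(=O)Nc1cc(Nc2nccc(-c3cn(C)c4ccccc34)n2)c(OC)cc1N(C)CCN(C)C` gives 1390 nM. Compound 2 `COc1cc(N(C)CCN(C)C)c(NC(=O)/C=C\C(C)C)cc1Nc1nccc(-c2cn(C)c3ccccc23)n1` gives 4390 nM. Compound 3 `C=C(Cl)C(=O)Nc1cc(Nc2ncc(C#N)c(-c3cn(C)c4ccccc34)n2)c(OC)cc1N(C)CCN(C)C` gives 115 nM, the lowest of the three numbers, and its gaps to compound 1 and to compound 2 both lie beyond the scatter. The step that sets compound 3 apart is a 12-fold lower number from compound 1 to compound 3 (1.08 log units; beyond the scatter).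

Compound 4 `COc1cc(N(C)CCN(C)C)c(NC(=O)/C=C\C(C)C)cc1Nc1ncc(C#N)c(-c2cn(C)c3ccccc23)n1` has not been measured. It differs from compound 3 in one place: 3-methylbut-1-en-1-yl in place of 1-chloroethenyl on a carbonyl carbon. Exactly this exchange of groups on the carbonyl carbon has been seen once before, between two compounds that lack the cyano group, and there it gave a 3.2-fold higher number from compound 1 to compound 2 (0.50 log units; beyond the scatter). Among the compounds with values here, that single precedent is the only guide, and nothing suggests the added cyano group should alter its size. A step of about the same size, in the same upward direction, is therefore expected, as a 3.2-fold higher number from compound 3 to compound 4 (0.51 log units; beyond the scatter). Compound 4 is accordingly estimated at 370 nM, with a likely range from 150 nM to 950 nM.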

Compound 4, half-maximal inhibitory concentration: 1810 nM
Estimate against measurement, compound 4: 4.9-fold (0.69 log units) below; the measured number lies above the stated range.
By their numbers in this assay, from the lowest: compound 3; then compounds 1 and 4 (each within the scatter of the next); then compound 2.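

In this assay, placing 3-methylbut-1-en-1-yl where 1-chloroethenyl stood on the carbonyl carbon costs far more when the cyano group is present, a 16-fold higher number from compound 3 to compound 4 (1.20 log units; beyond the scatter), so the size of this exchange depends on the rest of the molecule: the same change on two cores in this assay, a 3.2-fold higher number (0.50 log units; beyond the scatter) from compound 1 to compound 2 and a 16-fold higher number (1.20 log units; beyond the scatter) from compound 3 to compound 4, 5.0-fold (0.70 log units) apart, beyond the scatter of two such steps. Seen from the other side, the cyano group lowers the number less when 3-methylbut-1-en-1-yl is on the carbonyl carbon, a 2.4-fold lower number from compound 2 to compound 4 (0.38 log units; beyond the scatter), so the two changes do not simply add up: the same change on two cores in this assay, a 12-fold lower number (1.08 log units; beyond the scatter) from compound 1 to compound 3 and a 2.4-fold lower number (0.38 log units; beyond the scatter) from compound 2 to compound 4, 5.0-fold (0.70 log units) apart, beyond the scatter of two such steps. In these four compounds, neither change can be given a single fixed size.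

On these data alone, it remains open whether other groups on the carbonyl carbon, such as plain ethenyl or a longer chain ending in an amine, would show the same dependence on the cyano group. As far as these compounds go, it is equally open whether fluorine or methyl in place of cyano would do so, and these values cannot say why the two changes interact.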